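Kinetic solubility notes, compounds 1 to 4

The source may hold more compounds than are shown below. What is called first, only, known or untested is meant among the compounds shown, and "the series" means these compounds.

Compound 1 `CN1CC2(C1)CN(c1ccc(OCc3ccccc3)c(C(=O)Nc3ccnnc3)c1)C2` gives 198000 nM in a physicochemical assay for solubility, measured as kinetic solubility; a higher number here means a more soluble compound, a lower number a less soluble compound.
Compound 2 `O=C(Nc1ccnnc1)c1cc(N2CCC(F)CC2)ccc1OCc1ccccc1` gives 20000 nM.
Compound 3 `CN1CC2(CCN(c3ccc(OCc4ccccc4)c(C(=O)Nc4ccnnc4)c3)CC2)C1` gives 266000 nM.

Compound 3 stands at the top of the three numbers, yet one of the steps that lead to it, a 1.3-fold higher number from compound 1 to compound 3 (0.13 log units; within the scatter), is within the scatter; only the other, a 13-fold higher number from compound 2 to compound 3 (1.12 log units; beyond the scatter), is clear. Compound 4 `CN1CCN(c2ccc(OCc3ccccc3)c(C(=O)Nc3ccnnc3)c2)CC1` is the next variation: a group of 7 heavy atoms (5 carbon, 2 nitrogen; one six-membered non-aromatic ring with 2 hetero atoms) in place of a group of 10 heavy atoms (8 carbon, 2 nitrogen; one four-membered non-aromatic ring with 1 hetero atom, one six-membered non-aromatic ring with 1 hetero atom), on an aromatic carbon. The two steps that bear on it, a 9.9-fold lower number from compound 1 to compound 2 (1.00 log units; beyond the scatter) and a 13-fold higher number from compound 2 to compound 3 (1.12 log units; beyond the scatter), both turn on compound 2, whose group carries 1 nitrogen and 1 fluorine; the groups of compound 1, compound 3 and compound 4 each carry 2 nitrogens. For compound 4 a step of a 1.3-fold lower number from compound 3 to compound 4 (0.12 log units; within the scatter) is therefore expected, nothing beyond the scatter. The estimate for compound 4 is 200000 nM, with a range of 80000 nM to 420000 nM.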

Compound 4, solubility: 228000 nM
Compound 4: middle estimate off by 1.1-fold (0.06 log units), on the low side, and the stated range covers the measured number.
By their numbers in this assay, from the lowest: compound 2; then compounds 1, 4 and 3 (each within the scatter of the next).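

In this assay, 4-methylpiperazin-1-yl on this aromatic carbon reads level with the two larger groups that also carry two nitrogens: a 1.2-fold lower number from compound 3 to compound 4 (0.07 log units; within the scatter) and a 1.2-fold higher number from compound 1 to compound 4 (0.06 log units; within the scatter) both stay within the scatter. Within the data shown here, the single matched change from 4-fluoropiperidin-1-yl gives an 11-fold higher number from compound 2 to compound 4 (1.06 log units; beyond the scatter), so compound 2 now stands clearly below three compounds whose groups each carry two nitrogens. Nothing measured here accounts for that gap.

Still open, as far as these compounds go, is whether the fluorine or the absence of the second ring nitrogen separates compound 2 from the others. An unsubstituted piperidin-1-yl and a morpholin-4-yl at this position would help to distinguish the two.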